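Changing the aryl group on the shared core

A few compounds are considered here, and "the series" means these few. Any claim that something is new, unique, unknown or untested is made for them only; others in the source may bear on it.

Compound 1 `COc1ccc(-c2c(C)nn(-c3nc(-c4ccc(Cl)c(Cl)c4)c(SC(C)C)s3)c2C(=O)O)cc1` — 2100 nM
Compound 2 `Cc1cc(Cl)cc(-c2c(C)nn(-c3nc(-c4ccc(Cl)c(Cl)c4)c(SC(C)C)s3)c2C(=O)O)c1` — 663 nM
Compound 3 `Cc1nn(-c2nc(-c3ccc(Cl)c(Cl)c3)c(SC(C)C)s2)c(C(=O)O)c1-c1ccc(Cl)cc1` — 2500 nM

In a functional assay on BJAB cells (Homo sapiens) for antiproliferative activity, with a stated time of 4 days (on this read-out lower numbers stand for an effect already at smaller amounts and higher numbers for an effect only at larger amounts of compound), compound 1 gives 2100 nM, the second highest of the three numbers. Its nearest neighbour is compound 3 at 2500 nM, a step of a 1.2-fold higher number from compound 1 to compound 3 (0.08 log units; within the scatter), within the scatter. Furthest away lies compound 2, with a 3.2-fold lower number from compound 1 to compound 2 (0.50 log units; beyond the scatter).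

Compound 4 `Cc1nn(-c2nc(-c3ccc(Cl)c(Cl)c3)c(SC(C)C)s2)c(C(=O)O)c1-c1ccccc1Cl` differs from compound 1 by 2-chlorophenyl in place of 4-methoxyphenyl on an aromatic carbon. Among the compounds with values here, two measured steps bear on this place: a 1.2-fold higher number from compound 1 to compound 3 (0.08 log units; within the scatter) stays within the scatter, while a 3.2-fold lower number from compound 1 to compound 2 (0.50 log units; beyond the scatter) and a 3.8-fold higher number from compound 2 to compound 3 (0.58 log units; beyond the scatter) are modest. Within the data shown here, no measured compound carries 2-chlorophenyl, so the expectation is a small step at most, a 1.2-fold higher number from compound 1 to compound 4 (0.08 log units; within the scatter). Compound 4 is therefore estimated at 2500 nM, with a range from 1000 nM to 6500 nM.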

Compound 4, half-maximal effective concentration: 13100 nM
Estimate against measurement, compound 4: 5.2-fold (0.72 log units) below, outside the stated range (above it).
By their numbers in this assay, from the lowest: compound 2; then compounds 1 and 3 (each within the scatter of the next); then compound 4.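

In this assay this position proves sensitive to where the chloro sits on the phenyl ring: 2-chlorophenyl in place of 4-chlorophenyl brings a 5.2-fold higher number from compound 3 to compound 4 (0.72 log units; beyond the scatter) and in place of 4-methoxyphenyl brings a 6.2-fold higher number from compound 1 to compound 4 (0.80 log units; beyond the scatter) so the agreement between those two groups does not extend to 2-chlorophenyl. Set against 3-chloro-5-methylphenyl, the same group brings a 20-fold higher number from compound 2 to compound 4 (1.30 log units; beyond the scatter) and this is the largest step in the set. Nothing available explains why the 2-chlorophenyl group behaves differently.

On these data alone, whether 2-methoxyphenyl or 2-methylphenyl would follow 2-chlorophenyl remains open. So does the outcome of an amide in place of the carboxy group.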